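The source may report more compounds than this note shows. Statements on the series, on what has been measured and on what is new or still open speak of the compounds shown alone.

The measured compounds:
compound 1, `Cc1cc(Nc2nc(NCc3ccc(C#N)cc3)nc3ccccc23)n[nH]1`, which in an assay for inhibition of high affinity nerve growth factor receptor (Homo sapiens), read by HTRF, with a stated time of 30 min, in the presence of a further agent that is not named here (a higher number here means a weaker inhibitor, a lower number a stronger inhibitor), gives 83 nM
compound 2, `Cc1ccc(CNc2nc(Nc3cc(C)[nH]n3)c3ccccc3n2)cc1`, which gives 110 nM
compound 3, `Cc1cc(Nc2nc(NCc3ccc(C(F)(F)F)cc3)nc3ccccc23)n[nH]1`, which gives 1400 nM

Compound 1 shows the lowest number of the three. Compound 2 sits nearest to it, a 1.3-fold higher number from compound 1 to compound 2 (0.12 log units; within the scatter), and compound 3 furthest, a 17-fold higher number from compound 1 to compound 3 (1.23 log units; beyond the scatter); between those two, a 13-fold higher number from compound 2 to compound 3 (1.10 log units; beyond the scatter).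

Compound 4, `Cc1cc(Nc2nc(NCc3cc(F)cc(F)c3)nc3ccccc23)n[nH]1`, has not yet been measured. It differs from compound 1 in one place: 3,5-difluorophenyl in place of 4-cyanophenyl on a saturated chain carbon bound to a nitrogen on an aromatic ring. Within the data shown here, no measured step makes exactly this change. The two steps that bear on it both alter the substituent on that same aromatic carbon of the benzyl group. Exchanging cyano for methyl, a group with no hydrogen-bond acceptor, cost nothing beyond the scatter, while exchanging it for trifluoromethyl cost a great deal. A difluorophenyl with no acceptor lies between those two precedents, so compound 4 is expected to give a somewhat weaker result than compound 1, a 3.0-fold higher number from compound 1 to compound 4 (0.48 log units; beyond the scatter). Compound 4 is estimated at 250 nM, with a range from 80 nM to 800 nM.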

Compound 4, half-maximal inhibitory concentration: 170 nM
Beside the measured number, compound 4's estimate is 1.5-fold (0.17 log units) above it; the measured number falls inside the stated range.
By their numbers in this assay, from the lowest: compounds 1, 2 and 4 (each within the scatter of the next, the first and the last beyond it); then compound 3.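

In this assay, replacing 4-cyanophenyl with 3,5-difluorophenyl at this position gives a 2.0-fold higher number from compound 1 to compound 4 (0.31 log units; beyond the scatter) and so a modest step, which shows that a group without the nitrile and without a hydrogen-bond acceptor can stay close to compound 1. Set against 4-methylphenyl, the same group gives a 1.5-fold higher number from compound 2 to compound 4 (0.19 log units; within the scatter) and so cannot be told apart from it. Fluorine on this ring does not in itself carry the large penalty seen with trifluoromethyl, since compound 3 gives 1400 nM while compound 4 gives 170 nM in the same assay.

The compounds shown leave open how an unsubstituted phenyl, a methoxy group, an amine or a carboxylic acid would fare on this benzyl ring. No measurement here accounts for the differences among these groups.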